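This account rests on a few compounds, and the source may have more. Where it says the series, first, only, none or still open, it means among the compounds named here.

Within the data shown here, in a functional assay on KB cells (Homo sapiens) for inhibition, read by CellTiter-Blue, with a stated time of 96 h (on this read-out lower numbers stand for stronger inhibition and higher numbers for weaker inhibition), compound 1 `Nc1nc2[nH]c(CCCCCCCCC(=O)N[C@@H](CCC(=O)O)C(=O)O)cc2c(=O)[nH]1` gives 1.48 nM, a measured number, but no step connects it directly to the compounds that follow. Compound 2 `Nc1nc2[nH]c(CCCCCCC(=O)O)cc2c(=O)[nH]1` reads > 1000 nM, which is a limit of the assay. Compound 3 `Nc1nc2[nH]c(CCCCCCCC(=O)O)cc2c(=O)[nH]1` reads > 1000 nM, also a limit, so it has a bound and no number.

Compound 4 `Nc1nc2[nH]c(CCCCCCCCC(=O)O)cc2c(=O)[nH]1` differs from compound 3 by carboxymethyl in place of carboxy on a saturated chain carbon, seven bonds along the chain from an aromatic carbon. This is carboxymethyl in place of carboxy on a saturated chain carbon, seven bonds along the chain from an aromatic carbon.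

Among the measured compounds shown here, the one measured step that bears on this is a step that the two limits leave unreadable from compound 2 to compound 3. It is the same exchange, made six bonds along the chain from an aromatic carbon, and it offers neither a size nor a direction to carry over. What the series does show is the limit of > 1000 nM in this assay, at which 2 of the 3 values shown sit.

With compound 3 at > 1000 nM, a limit, compound 4 is expected to remain weak in this assay, and a shift towards the value of compound 1 is not anticipated. The expected change is a step that the limit leaves unreadable from compound 3 to compound 4. For compound 4 the estimated half-maximal inhibitory concentration is 2000 nM, with an expected range from 500 nM to 10000 nM.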

Compound 4, half-maximal inhibitory concentration: > 1000 nM
Compound 4: no number, only a limit; the forecaster's own chance of this, stated with the estimate: 85%; the middle value is on the limit's open side.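

In this assay compound 4 reads > 1000 nM, which is a limit of the assay. The steps among compound 2, compound 3 and compound 4 cannot be read, so carboxymethyl in place of carboxy at this position, seven bonds along the chain from an aromatic carbon, gives neither a size nor a direction, and this further chain with a free carboxy end adds to what the series already showed: the limit of > 1000 nM in this assay, at which 3 of the 4 values shown sit. The series also gains a readable step at this chain length: with hydroxy in place of (1,3-dicarboxypropyl)amino on the carbonyl carbon, the read-out shows an at least 670-fold higher number from compound 1 to compound 4 (2.82 log units; beyond the scatter).

The compounds shown leave open how those with a free carboxy end rank against one another, since their true values lie beyond the limit. They also leave open whether a simple methyl amide on the same carbonyl carbon would keep any of the strength of compound 1, and whether the (1,3-dicarboxypropyl)amino group would give a similar result on a shorter or a longer chain.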